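A few compounds are considered here, and "the series" means these few. Any claim that something is new, unique, unknown or untested is made for them only; others in the source may bear on it.

Working notes on the series. Of the compounds shown here, two of this set have been measured in a functional assay on HCT-116 cells (Homo sapiens) for inhibition, read by sulforhodamine B assay, with a stated time of 48 h, tested at 50 uM; a higher number here means more inhibition of growth at the concentration tested, a lower number less inhibition of growth. Compound 1, `COc1ccccc1/C=C/C(=O)/C=C/c1ccc(OCc2cn(CCOc3cc(=O)oc4ccccc34)nn2)c(OC)c1`, gives 70% in this assay. Compound 2, `COc1ccc(/C=C/C(=O)/C=C/c2ccc(OCc3cn(CCCOc4cc(=O)oc5ccccc45)nn3)c(OC)c2)cc1OC`, gives 67% in this assay; the gap between the numbers of compound 1 and compound 2 falls within the usual scatter of repeated measurements, so the two read as equivalent on the data at hand, and compound 1 is taken simply as the measured reference for the next step.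

The step considered leads from compound 1 to compound 3, `COc1cc(/C=C/C(=O)/C=C/c2ccco2)ccc1OCc1cn(CCOc2cc(=O)oc3ccccc23)nn1`. The structural change is furan-2-yl in place of 2-methoxyphenyl on a double-bonded chain carbon bound to a double-bonded chain carbon. Going by the values given here, no measured pair in the set shares this change, so no step for it is known; what compound 1 and compound 2 show is only that the two measured members sit close together in this assay.

For compound 3 the step is expected to be a number 8 percentage points lower from compound 1 to compound 3 (within the scatter), a modest move downward that may not exceed the scatter. Compound 3 is therefore estimated at 62% in this assay, with a range from 42% to 80%.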

Compound 3, percent growth inhibition at one concentration: 72%
The estimate for compound 3 lay 10 percentage points below the measured number; low and high end bracket the measured number.
By their numbers in this assay, from the lowest: compounds 2, 1 and 3 (each within the scatter of the next).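

In this assay, going by these compounds alone, furan-2-yl in place of 2-methoxyphenyl on a double-bonded chain carbon bound to a double-bonded chain carbon gives a number 2 percentage points higher from compound 1 to compound 3 (within the scatter) and is the first step that can be read at this place. It shows that compound 1 and compound 3 read as equivalent even though the entering group is a five-membered aromatic ring with 1 hetero atom and 5 heavy atoms, while the leaving group is a six-membered aromatic ring of carbon only with 8 heavy atoms. The evidence at hand offers no explanation for this equivalence.

The compounds shown leave open whether an aromatic ring is needed at this place at all, and whether a cyclohexyl group, a dimethylaminophenyl group or a carboxylic acid there would stay level with compound 1. Because the read-out is percent growth inhibition at a single concentration, they also leave open whether compound 1 and compound 3 would still read as equivalent across a range of concentrations.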